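The compounds below may be only part of what the source reports. "The series", "measured", "known", "first", "only" and "open" are said of these compounds alone.

Compound 1 `C=CCc1cc(C(C)=O)c(O)cc1OCCCC#N` gives 6% in an assay on isolated protein for binding affinity to leukotriene B4 receptor 1 (Homo sapiens), tested at 1 uM; a lower number here means less inhibition, a higher number more inhibition at the concentration tested (going by the name of the read-out). Going by the values given here, this is the lower of the two numbers known so far: compound 2 `CCc1cc(C(C)=O)c(O)cc1OCCCC(C)(C)c1nnn[nH]1` gives 76% in this assay. Compound 3 `C=CCc1cc(C(C)=O)c(O)cc1OCCCCO` has not yet been measured. It differs from compound 1 by hydroxymethyl in place of cyano on a saturated chain carbon, three bonds along the chain from an oxygen on an aromatic ring. Among the compounds with values here, no measured pair shows this exchange, so the expectation rests on compound 1 alone. The step is expected to stay within the scatter, a number 4 percentage points higher from compound 1 to compound 3 (within the scatter), since the starting point is low because compound 1 gives 6%. Compound 3 is estimated at 10% in this assay, between 0% and 30%.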

Compound 3, a percentage reported as inhibition, at one concentration (the size of the read-out at that concentration, not a potency): 9%
Beside the measured number, compound 3's estimate is 1 percentage points above it, and the stated range covers the measured number.
By their numbers in this assay, from the lowest: compounds 1 and 3 (each within the scatter of the next); then compound 2.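

Replacing the 3-cyanopropyl chain with the 4-hydroxybutyl chain gives a number 3 percentage points higher from compound 1 to compound 3 (within the scatter) in this assay and so does not separate the two compounds. At this chain end, a hydrogen-bond donor enters and the nitrile's triple bond leaves, yet the read-out stays within the scatter. No supporting measurement bears on this result.

Going by these compounds, whether a carboxylic acid or an amine at this chain end, or a longer chain, would shift the read-out remains open. Compound 2 differs from compound 1 in more than one place, so its higher value cannot be assigned to the chain end alone.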